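Swapping a Bromo for a Substituted Phenyl Group

The source may hold more compounds than are shown below. What is called first, only, known or untested is meant among the compounds shown, and "the series" means these compounds.

Measured compounds:
compound 1 `Brc1cn2ccnc2c(-c2ccc3ncn(C4CCCCC4)c3c2)n1`: 6.64%
compound 2 `COc1ccc(-c2cn3ccnc3c(-c3ccc4ncn(C5CCCCC5)c4c3)n2)cc1`: 58.8%

Two measured compounds share the same core and differ in a single group on an aromatic carbon. In a functional assay on OVCAR-5 cells (Homo sapiens) for inhibition, read by sulforhodamine B assay, with a stated time of 48 h, tested at 10 uM (a higher number here means more inhibition at the concentration tested (going by the name of the read-out), a lower number less inhibition), compound 1 gives 6.64%, the lowest of the two numbers shown. Its nearest neighbour is compound 2, which gives 58.8% in this assay. Going by the values given here, the only measured step, a number 52.2 percentage points higher from compound 1 to compound 2 (beyond the scatter), shows that replacing the bromo with a six-membered aromatic carbon ring carrying a methoxy group lifts inhibition strongly.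

The unmeasured compound 3 `Brc1ccc(-c2cn3ccnc3c(-c3ccc4ncn(C5CCCCC5)c4c3)n2)cc1` differs from compound 1 in one place: 4-bromophenyl in place of bromo on an aromatic carbon. This change resembles the step from compound 1 to compound 2 in that a small bromo is again replaced by a substituted phenyl ring, differing only in what that ring carries. Among the compounds with values here, because a number 52.2 percentage points higher from compound 1 to compound 2 (beyond the scatter) was large, a rise in this assay is expected for compound 3, plausibly somewhat smaller than that step since the substituent on the ring is different and only one comparison exists. The expected step is a number 38.4 percentage points higher from compound 1 to compound 3 (beyond the scatter). For compound 3 the estimate in this assay is 45%, with a range from 15% to 75%.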

Compound 3, a percentage reported as inhibition, at one concentration (the size of the read-out at that concentration, not a potency): 8.95%
Estimate against measurement, compound 3: 36.1 percentage points above; the whole stated range lies above it.
By their numbers in this assay, from the lowest: compounds 1 and 3 (each within the scatter of the next); then compound 2.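

In this assay a phenyl ring at this position does not by itself raise the read-out: 4-bromophenyl in place of bromo gives a number 2.3 percentage points higher from compound 1 to compound 3 (within the scatter) and so leaves compound 3 indistinguishable from compound 1. What separates the two phenyl compounds is the group on the ring, as bromo in place of methoxy gives a number 49.9 percentage points lower from compound 2 to compound 3 (beyond the scatter) and thus shows that the high number of compound 2 goes with the 4-methoxyphenyl group as a whole, not with the added ring alone. Nothing available here explains why these two ring substituents give such different numbers.

The compounds shown leave open whether a hydroxyl, an amine or a fluoro group on the same phenyl ring would give a number like that of compound 2 or one like that of compound 3. They also leave open whether a longer chain such as ethoxy in place of the methoxy would keep the inhibition seen with compound 2, and whether the methoxy group would give the same result elsewhere on the ring.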